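The source may report more compounds than this note shows. Statements on the series, on what has been measured and on what is new or still open speak of the compounds shown alone.

Compound 1 `CCOC(=O)C1=Cc2ccccc2OC1(OCc1cc(-c2ccc(F)cc2F)no1)C(F)(F)F`: > 150000 nM
Compound 2 `CCOC(=O)C1=Cc2ccccc2OC1(OCc1cc(-c2ccc(OC)cc2)no1)C(F)(F)F`: > 150000 nM

Both compounds were tested in a functional assay on MCF7 cells (Homo sapiens) for inhibition, read by MTT assay, with a stated time of 24 h; on this read-out higher numbers stand for weaker inhibition and lower numbers for stronger inhibition. For compound 1 the value > 150000 nM is a limit of the assay, not a number. For compound 2 the value > 150000 nM is likewise a limit, not a number. This is the whole picture: the limit of > 150000 nM in this assay, at which 2 of the 2 values shown sit. Compound 2 therefore stands at the limit, with no number of its own to place it against anything else. Within the data shown here, the one measured step, a step that the two limits leave unreadable from compound 1 to compound 2, joins two limits and has no readable size.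

Compound 3 `CCOC(=O)C1=Cc2ccccc2OC1(OCc1cc(-c2ccc(Cl)cc2)no1)C(F)(F)F` is a new variation on compound 2, differing by chloro in place of methoxy on an aromatic carbon. Among the measured compounds shown here, the only measured step, a step that the two limits leave unreadable from compound 1 to compound 2, also changes the group on that ring, but it gives no size and no direction, so it cannot set an expectation beyond the limit itself. With both known values at the limit, the expected step of a number no higher from compound 2 to compound 3 (the limit leaves the size open) is none beyond the scatter, and compound 3 is most likely to return a limit as well. Compound 3 is estimated at 150000 nM, with a range from 50000 nM to 300000 nM.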

Compound 3, half-maximal inhibitory concentration: 18200 nM
Compound 3: middle estimate off by 8.2-fold (0.92 log units), on the high side; measured number outside the range, below it.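

In this assay the aromatic carbon para to a large group proves able to shift the read-out: chloro in place of methoxy gives an at least 8.2-fold lower number from compound 2 to compound 3 (0.91 log units; beyond the scatter) and 4-chlorophenyl in place of 2,4-difluorophenyl gives an at least 8.2-fold lower number from compound 1 to compound 3 (0.91 log units; beyond the scatter) on the same scaffold. Among these compounds, the earlier pair could not show this, as its step cannot be read, so compound 3 is the first compound here with a number of its own and the first evidence that the group on this ring can matter at all. Both steps remain minimum sizes, and the true gaps could be larger, since the other two compounds give no number to measure from: the limit of > 150000 nM in this assay, at which 2 of the 3 values shown sit.

The compounds shown leave open whether chloro is unusual at this carbon or whether bromo, a nitrile, an amine or a carboxylic acid there would give a similar or lower number. They also leave open whether the shared core tolerates change elsewhere, for example a longer chain in the ester, and whether the 4-chlorophenyl gain would carry over to such compounds.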